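A few compounds are considered here, and "the series" means these few. Any claim that something is new, unique, unknown or untested is made for them only; others in the source may bear on it.

Measured compounds in the series:

- compound 1 `CCn1c(C(=O)NCCN)ccc1C(CC)(CC)c1ccc(OCCC(O)(CC)CC)c(C)c1`: 1740 nM
- compound 2 `CCOC(=O)CN(C)C(=O)c1ccc(C(CC)(CC)c2ccc(OCCC(O)(CC)CC)c(C)c2)n1CC`: 30300 nM

Among the measured compounds shown here, in a functional assay on Caco-2 cells (Homo sapiens) for antiproliferative activity, read by MTT assay, with a stated time of 48 h (on this read-out higher numbers stand for weaker inhibition and lower numbers for stronger inhibition), compound 1 gives 1740 nM and stands as the lowest of the two numbers so far; the nearest neighbour is compound 2, which in this assay gives 30300 nM. For the measured compounds named here, the one measured step, a 17-fold higher number from compound 1 to compound 2 (1.24 log units; beyond the scatter), came with ((ethoxycarbonyl)methyl)(methyl)amino in place of (2-aminoethyl)amino on a carbonyl carbon, and it is the only step in hand.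

Compound 3 `CCn1c(C(=O)NC(C)C(=O)O)ccc1C(CC)(CC)c1ccc(OCCC(O)(CC)CC)c(C)c1` has not been measured. It differs from compound 1 by 1-carboxyethyl in place of 2-aminoethyl on an amide-type nitrogen. The measured step from compound 1 to compound 2 bears on this only loosely: it also removes the (2-aminoethyl)amino group, but what enters there is not what enters in compound 3, and the amide-type nitrogen also carries a methyl in compound 2. The direction of that step is taken as a guide, its full size is not. A higher number than for compound 1 is expected in this assay, smaller than a 17-fold higher number from compound 1 to compound 2 (1.24 log units; beyond the scatter) but beyond the scatter, giving an expected 4.6-fold higher number from compound 1 to compound 3 (0.66 log units; beyond the scatter). Compound 3 is thus estimated at 8000 nM, with a range from 2500 nM to 25000 nM.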

Compound 3, half-maximal inhibitory concentration: 46500 nM
Estimate against measurement, compound 3: 5.8-fold (0.76 log units) below, outside the stated range (above it).
By their numbers in this assay, from the lowest: compound 1; then compounds 2 and 3 (each within the scatter of the next).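

In this assay, a second replacement of 2-aminoethyl on the amide-type nitrogen now points the same way as the first: 1-carboxyethyl gives a 27-fold higher number from compound 1 to compound 3 (1.43 log units; beyond the scatter), a large step of the same order as a 17-fold higher number from compound 1 to compound 2 (1.24 log units; beyond the scatter), so compound 1 alone holds the low number among the three compounds. The two replacements are not separated from each other, since (1-carboxyethyl)amino in place of ((ethoxycarbonyl)methyl)(methyl)amino gives a 1.5-fold higher number from compound 2 to compound 3 (0.19 log units; within the scatter), and the difference between a free carboxyl group with the amide hydrogen kept and an ethyl ester with a methyl on that nitrogen does not show in this read-out. No evidence at hand bears on the cause of these steps.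

From the compounds shown here alone, it remains open whether the low number of compound 1 depends on the terminal amine itself or on the chain that carries it, which a 2-hydroxyethyl, a 3-aminopropyl or a 2-(dimethylamino)ethyl group on the same nitrogen would separate. Going by these compounds, it is also open whether the ethyl ester of the 1-carboxyethyl group would stay with compound 3 in this assay.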